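A methyl group replaces a fluorine on the aryl arm

The compounds below may be only part of what the source reports. "The series", "measured", "known", "first", "only" and "open" are said of these compounds alone.

Three compounds with a shared core were tested in an assay for inhibition of histone-lysine N-methyltransferase, H3 lysine-79 specific (Homo sapiens), read by scintillation counting, with stated times of 15 min and 60 min, tested at 50 uM, in the presence of a further agent that is not named here; a lower number here means a weaker effect, a higher number a stronger effect of the compound at the concentration tested. Compound 1 `Cc1occc1-c1nnc2sc(CCCc3ccccc3)nn12` gives 17%, compound 2 `COc1ccccc1-c1nnc2sc(/C=C/c3ccco3)nn12` gives 75%, and compound 3 `Fc1ccc(-c2nnc3sc(/C=C/c4ccco4)nn23)cc1` gives 44%. Among these three numbers compound 3 stands second highest: its nearest neighbour is compound 1, lower by a margin beyond the usual scatter, and its furthest is compound 2, higher by a margin also beyond that scatter. Compound 4 `Cc1cccc(-c2nnc3sc(/C=C/c4ccco4)nn23)c1` is not yet measured. It differs from compound 3 in one place: 3-methylphenyl in place of 4-fluorophenyl on an aromatic carbon. Among the compounds with values here, no step between measured compounds that differ in one place is available as a guide. The change from compound 3 to compound 4 is expected to be small, possibly none beyond the scatter, as a number 6 percentage points higher from compound 3 to compound 4 (within the scatter). Compound 4 is expected to give 50% in this assay, within a range from 25% to 75%.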

Compound 4, a percentage reported as inhibition, at one concentration (the size of the read-out at that concentration, not a potency): 69%
Compound 4: the middle estimate sits 19 percentage points below what was measured; measured number inside the range.
By their numbers in this assay, from the lowest: compound 1; then compound 3; then compounds 4 and 2 (each within the scatter of the next).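

In this assay, within the data shown here, the step of a number 25 percentage points higher from compound 3 to compound 4 (beyond the scatter) gives the first one-place comparison here, showing that this aromatic carbon of the five-membered ring responds to the choice of aryl group. The 4-fluorophenyl and 3-methylphenyl groups have the same heavy-atom count and the same carbon ring, yet the read-out moves beyond the scatter. No measurement shown explains this gain. Going by these compounds, whether it follows the added methyl, the lost fluorine or the different place of the group stays open, as does how a phenyl carrying a chlorine or an amine would read.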